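Indole replacing benzofuran on the amide carbonyl

The source may hold more compounds than are shown below. What is called first, only, known or untested is meant among the compounds shown, and "the series" means these compounds.

Among the measured compounds shown here, compound 2 `CN1[C@@H]2c3[nH]c4ccccc4c3C[C@H]1[C@H](C#N)N1[C@@H](CNC(=O)c3cc4ccccc4o3)c3[nH]c4ccccc4c3C[C@@H]21` gives 230 nM in a functional assay on A2780 cells (Homo sapiens) for cytotoxicity, read by MTT assay, with a stated time of 72 h (a higher number here means a weaker inhibitor, a lower number a stronger inhibitor), the lowest of the two numbers known; the nearest is compound 1 `CN1[C@@H]2c3[nH]c4ccccc4c3C[C@H]1[C@H](C#N)N1[C@@H](CNC(=O)c3ccc4ccccc4c3)c3[nH]c4ccccc4c3C[C@@H]21`, which gives 1030 nM. For the measured compounds named here, the one step known, a 4.5-fold lower number from compound 1 to compound 2 (0.65 log units; beyond the scatter), bears only loosely on the change to compound 3 `CN1[C@@H]2c3[nH]c4ccccc4c3C[C@H]1[C@H](C#N)N1[C@@H](CNC(=O)c3cc4ccccc4[nH]3)c3[nH]c4ccccc4c3C[C@@H]21`, described as 1H-indol-2-yl in place of 1-benzofuran-2-yl on a carbonyl carbon. Going by the values given here, no step between an indole and a benzofuran has been measured here, so the expectation rests on compound 2 alone, and the step of a 1.1-fold higher number from compound 2 to compound 3 (0.04 log units; within the scatter) is expected to stay within the scatter. Compound 3 is therefore estimated at 250 nM, within 80 nM to 800 nM.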

Compound 3, half-maximal inhibitory concentration: 7100 nM
Compound 3: the middle estimate sits 28-fold (1.45 log units) below what was measured; the measured number lies above the stated range.
By their numbers in this assay, from the lowest: compound 2; then compound 1; then compound 3.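

In this assay, this place on the carbonyl carbon proves highly sensitive to a single ring atom: the oxygen-to-nitrogen exchange, with the heavy-atom count unchanged, gives a 31-fold higher number from compound 2 to compound 3 (1.49 log units; beyond the scatter). The indole also falls short of the naphthalene, with a 6.9-fold higher number from compound 1 to compound 3 (0.84 log units; beyond the scatter), making compound 3 the weakest of the three. Nothing measured here explains this loss. As far as these compounds go, whether it follows the indole ring hydrogen remains open, and 1-methyl-1H-indol-2-yl or 1-benzothiophen-2-yl at the same place would bear on that question.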